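This account rests on a few compounds, and the source may have more. Where it says the series, first, only, none or still open, it means among the compounds named here.

Compound 1 `O=C(CCC1=CCN(CCCc2ccc(Cl)cc2)C1=O)NO`: 3480 nM
Compound 2 `O=C(CCC1=CCN(Cc2ccc(Br)cc2F)C1=O)NO`: 4620 nM
Compound 3 `N#Cc1cccc(CN2CC=C(CCC(=O)NO)C2=O)c1`: 7920 nM

All three were tested in a functional assay on PC-3 cells (Homo sapiens) for inhibition, read by sulforhodamine B assay; on this read-out higher numbers stand for weaker inhibition of growth and lower numbers for stronger inhibition of growth. Compound 1 shows the lowest number of the three. Compound 2 sits within the scatter of it, so no order between them can be claimed, while compound 3 lies beyond the scatter at a higher number. Compound 4 `Cc1ccc(CCCN2CC=C(CCC(=O)NO)C2=O)cc1` has not yet been measured. It differs from compound 1 in a single place: methyl in place of chloro on an aromatic carbon. Among the compounds with values here, each group counts one heavy atom, and none of the measured pairs shows what such a swap does here. The expected step in this assay is a 1.3-fold higher number from compound 1 to compound 4 (0.11 log units; within the scatter), no more than the scatter in either direction. Compound 4 is thus estimated at 4500 nM, with a range from 2000 nM to 10000 nM.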

Compound 4, concentration for 50% growth inhibition: 3480 nM
For compound 4 the middle estimate is 1.3-fold (0.11 log units) above the measured one, and the stated range covers the measured number.
By their numbers in this assay, from the lowest: compounds 1, 4, 2 and 3 (each within the scatter of the next, the first and the last beyond it).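

In this assay there is no change at the digits printed from compound 1 to compound 4 (within the scatter) when 4-chlorophenyl becomes 4-methylphenyl. Within the data shown here, this is the first pair here that differs in one place only, and it shows that at this position on the aromatic ring, chloro and methyl cannot be told apart by this read-out. Nothing available explains why the two groups read alike.

As far as these compounds go, whether an amine or a carboxylic acid at this position would shift the number remains open. So does the effect of a longer chain leading to this ring.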